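This account rests on a few compounds, and the source may have more. Where it says the series, first, only, none or still open, it means among the compounds named here.

Compound 1 `CC(=O)OCCn1nc(-c2cccnc2)c2ccccc2c1=O`: 9770 nM
Compound 2 `CCOC(=O)CCCn1nc(-c2cccnc2)c2ccccc2c1=O`: 10000 nM

In a functional assay (trachea) with Cavia porcellus as the target (a higher number here means a weaker inhibitor, a lower number a stronger inhibitor), compound 2 gives 10000 nM, level with compound 1 within the scatter. Next is compound 3 `O=C(c1cccs1)n1nc(-c2cccnc2)c2ccccc2c1=O`, with (thiophen-2-yl)carbonyl in place of 3-(ethoxycarbonyl)propyl on an aromatic nitrogen.

Among the measured compounds shown here, only one measured step bears on this, a 1.0-fold higher number from compound 1 to compound 2 (0.01 log units; within the scatter), and it lies within the scatter. It exchanged one ester chain for another, so it covers a carbonyl attached directly to the aromatic nitrogen only loosely. No step beyond the scatter is expected, and no direction is favoured. The expected step is a 1.3-fold lower number from compound 2 to compound 3 (0.10 log units; within the scatter). For compound 3 the estimate is 8000 nM, with an expected range of 2000 nM to 30000 nM.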

Compound 3, half-maximal inhibitory concentration: 12300 nM
For compound 3 the middle estimate is 1.5-fold (0.19 log units) below the measured one; the measured number falls inside the stated range.
By their numbers in this assay, from the lowest: compounds 1, 2 and 3 (each within the scatter of the next).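

Placing (thiophen-2-yl)carbonyl on the aromatic nitrogen leaves the number in this assay within the scatter of both ester chains (a 1.2-fold higher number from compound 2 to compound 3 (0.09 log units; within the scatter); a 1.3-fold higher number from compound 1 to compound 3 (0.10 log units; within the scatter)). This position therefore accepts a carbonyl attached directly to the nitrogen and a five-membered aromatic ring without a change beyond the scatter, extending the flat result from the saturated ester chains. No supporting data bear on why the number stays level.

Still open, on these data alone, is whether an amine or a carboxylic acid on this nitrogen would move the number beyond the scatter. Replacing the pyridin-3-yl group with another group also remains untested among the compounds shown.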